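Shortening the hydroxycarbamoyl chain of compound 3

The compounds below may be only part of what the source reports. "The series", "measured", "known", "first", "only" and "open" are said of these compounds alone.

Growth inhibition in a functional assay on Hep 3B2 cells (Homo sapiens) for antiproliferative activity, read by sulforhodamine B assay, with a stated time of 48 h; a higher number here means a weaker inhibitor of growth, a lower number a stronger inhibitor of growth:
Compound 1 `CC(C)CCc1c(OCCCCCCC(=O)NO)ccc2c1OC(=O)CC2`: > 30000 nM, a limit
Compound 2 `CC(C)CCc1c(OCCCCCCCC(=O)NO)ccc2ccc(=O)oc12`: 3580 nM
Compound 3 `CC(C)CCc1c(OCCCCCC(=O)NO)ccc2c1OC(=O)CC2`: > 30000 nM, a limit
Compound 4 `CC(C)CCc1c(OCCCCC(=O)NO)ccc2c1OC(=O)CC2`: not yet measured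

Compound 3 stands only at a limit, > 30000 nM. Compound 2 alone gives a number, 3580 nM. Compound 4 follows from compound 3 through (hydroxycarbamoyl in place of (hydroxycarbamoyl)methyl on a saturated chain carbon, four bonds along the chain from an oxygen on an aromatic ring). Going by the values given here, the one measured step that bears on this is the same exchange made five bonds along the chain, a step that the two limits leave unreadable from compound 1 to compound 3. It offers no size to carry over, and the limit of > 30000 nM in this assay, at which 2 of the 3 values shown sit, marks where both saturated-core neighbours rest. No step beyond the scatter can therefore be expected in this assay, and any direction would be a guess. The expected step is a number no higher from compound 3 to compound 4 (the limit leaves the size open). Compound 4 is estimated at 30000 nM, with an expected range of 12000 nM to 60000 nM.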

Compound 4, concentration for 50% growth inhibition: > 30000 nM
Compound 4: a limit, no number; the forecaster's own chance of this, stated with the estimate: 80%; the middle value lies on the limit itself.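

In this assay compound 4 gives > 30000 nM, a limit, and its steps from compound 3 and compound 1 cannot be read. The compounds shown leave open whether chain length changes growth inhibition on the core of compound 4 at all.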